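The source may hold more compounds than are shown below. What is called first, only, known or untested is meant among the compounds shown, and "the series" means these compounds.

Values measured so far in a functional assay on HT-29 cells (Homo sapiens) for antiproliferative activity; a lower number here means a stronger inhibitor of growth, a higher number a weaker inhibitor of growth

Compound 1 `c1ccc(-c2cc(-c3ccsc3)cc(-c3cccnc3)n2)nc1` gives 0.36 ug/mL
Compound 2 `c1ccc(-c2cc(-c3ccco3)cc(-c3ccccn3)n2)nc1` gives 0.0024 ug/mL
Compound 3 `c1ccc(-c2cc(-c3ccoc3)cc(-c3ccccn3)n2)nc1` gives 0.0026 ug/mL

Compound 1 has the highest number of the three, so it is the weakest growth inhibitor here. Its value lies well beyond the scatter from those of compound 2 and compound 3, which match each other within the scatter.

The compound still to be measured is compound 4 `c1ccc(-c2cc(-c3cccs3)cc(-c3cccnc3)n2)nc1`, which has the same atoms as compound 1, joined differently. The change is thiophen-2-yl in place of thiophen-3-yl on an aromatic carbon and it sits opposite the ring nitrogen.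

Within the data shown here, no thiophene pair has been measured, so the nearest guide is a furan pair that makes the same kind of swap. That step is a 1.1-fold higher number from compound 2 to compound 3 (0.03 log units; within the scatter) and it stays within the scatter. This guide is indirect, since compound 2 and compound 3 carry a different ring and a different core from compound 1, and their numbers are far lower. Even so, it gives no reason to expect a real shift in this assay or to favour either direction.

The expected step is no change at the digits printed from compound 1 to compound 4 (within the scatter) and so none beyond the scatter. The estimated value for compound 4 is 0.36 ug/mL with an expected range from 0.12 ug/mL to 1.1 ug/mL.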

Compound 4, concentration for 50% growth inhibition: 0.19 ug/mL
The estimate for compound 4 lay 1.9-fold (0.28 log units) above the measured number; low and high end bracket the measured number.
By their numbers in this assay, from the lowest: compounds 2 and 3 (each within the scatter of the next); then compounds 4 and 1 (each within the scatter of the next).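

In this assay, moving the attachment point of the thiophene at this position, opposite the ring nitrogen, gives a 1.9-fold lower number from compound 1 to compound 4 (0.28 log units; within the scatter), so thiophen-2-yl and thiophen-3-yl cannot be told apart here. This is a direct thiophene result where earlier there was only the indirect guide of the furan pair, and together with a 1.1-fold higher number from compound 2 to compound 3 (0.03 log units; within the scatter) it gives two pairs in which changing the attachment point of the five-membered ring leaves the number within the scatter. No measured evidence is available to explain this outcome.

The compounds shown carry only five-membered aromatic rings at this position, so it remains open what a phenyl ring, a morpholine or a longer chain such as an aminoethyl group would do here. As far as these compounds go, it is also open whether the two thiophene compounds would stay this close with a pyridin-2-yl group in place of their pyridin-3-yl group.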